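The source may hold more compounds than are shown below. What is called first, only, known or untested is meant among the compounds shown, and "the series" means these compounds.

Compound 1 `O=C(O)c1ccc(C(=O)/C(=C\c2ccc(F)c([N+](=O)[O-])c2)SCc2ccc(C(F)(F)F)cc2)cc1` and compound 2 `O=C(O)c1ccc(C(=O)/C(=C\c2ccc(F)c([N+](=O)[O-])c2)SCc2ccc(F)cc2)cc1` share one core. In a functional assay on DU-145 cells (Homo sapiens) for inhibition, read by trypan blue exclusion, with a stated time of 96 h (a higher number here means a weaker inhibitor of growth, a lower number a stronger inhibitor of growth), compound 2 gives 1000 nM. Compound 1 gives 1000 nM in this assay. The change trifluoromethyl in place of fluoro on an aromatic carbon thus makes the step of no change at the digits printed from compound 2 to compound 1 (within the scatter). Compound 3 `Cc1ccc(S/C(=C/c2ccc(F)cc2F)C(=O)c2ccc(Br)cc2)cc1` is built on a different core; the difference between the two cores is not broken down here. For compound 3, this assay reports only a limit, > 100000 nM, that is the limit of > 100000 nM in this assay, at which 1 of the 3 values shown sits. Compound 4 `Cc1ccc(S/C(=C/c2ccc(F)cc2C(F)(F)F)C(=O)c2ccc(Br)cc2)cc1` is not yet measured. It differs from compound 3 by trifluoromethyl in place of fluoro on an aromatic carbon, the same kind of change as from compound 2 to compound 1, though there the group sits para to a large group and here ortho to a large group and meta to a fluoro group. The step is expected to be a step that the limit leaves unreadable from compound 3 to compound 4, resting on the earlier no change at the digits printed from compound 2 to compound 1 (within the scatter). Compound 4 is expected near 150000 nM, between 50000 nM and 500000 nM, most likely again only a limit.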

Compound 4, concentration for 50% growth inhibition: 25000 nM
Compound 4: the middle estimate sits 6.0-fold (0.78 log units) above what was measured, outside the stated range (below it).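

Trifluoromethyl in place of fluoro on an aromatic carbon gives an at least 4.0-fold lower number from compound 3 to compound 4 (0.60 log units; beyond the scatter) in this assay. The change therefore does not carry over with the same result from one core to the other: the same change on two cores in this assay, no change at the digits printed (within the scatter) from compound 2 to compound 1 and an at least 4.0-fold lower number (0.60 log units; beyond the scatter) from compound 3 to compound 4, at least 4.0-fold (0.60 log units) apart, beyond the scatter of two such steps For compound 3, > 100000 nM is a limit, so the full size of the step stays unknown, and the gap between the steps cannot be assigned to the core alone, as the group also sits at a different place on each core: the limit of > 100000 nM in this assay, at which 1 of the 4 values shown sits.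

Open, going by these compounds, is whether a nitrile or a methoxy group at the same place on the core of compound 3 would give a step like that of trifluoromethyl. Also open, on these data alone, is how the change behaves at other places on either core.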